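The compounds below may be only part of what the source reports. "The series", "measured", "known", "first", "only" and "open" are said of these compounds alone.

Compound 1, `COc1cc(OC)c2c(=O)cc(/C=C/c3ccncc3)oc2c1`: > 40000 nM
Compound 2, `COc1cc(OC)c2c(=O)cc(/C=C/c3ccc(OCC4CC4)cc3)oc2c1`: 22100 nM
Compound 3, `COc1cc(OC)c2c(=O)cc(/C=C/c3ccccc3)oc2c1`: 26000 nM

All three share one core and differ only in the ring at the end of the double-bonded chain. In a functional assay on SKHep cells (Homo sapiens) for antiproliferative activity, read by MTT assay, with a stated time of 12 h (a lower number here means a stronger inhibitor, a higher number a weaker inhibitor), compound 1 gives > 40000 nM, which is a limit of the assay and not a number. Compound 3 gives 26000 nM; the change from the pyridine ring to phenyl is an at least 1.5-fold lower number from compound 1 to compound 3 (0.18 log units; that floor lies within the scatter). Compound 2 gives 22100 nM, and compound 3 sits within the scatter of it (a 1.2-fold higher number from compound 2 to compound 3 (0.07 log units; within the scatter)), so the two cannot be told apart.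

Compound 4, `COc1cc(OC)c2c(=O)cc(/C=C/c3ccc(Br)cc3)oc2c1`, has not yet been measured. It differs from compound 2 in one place: bromo in place of cyclopropylmethoxy on an aromatic carbon. For the measured compounds named here, no measured step puts bromo onto this ring, so the only guide is a 1.2-fold higher number from compound 2 to compound 3 (0.07 log units; within the scatter), where the same group is removed and little changes. A step of similar size, in no clear direction, is therefore expected. Compound 4 is expected to give about 20000 nM, between 8000 nM and 50000 nM. That estimate corresponds to an expected 1.1-fold lower number from compound 2 to compound 4 (0.04 log units; within the scatter), staying within the scatter.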

Compound 4, half-maximal inhibitory concentration: > 40000 nM
Compound 4 ended at the assay's limit; the forecaster's own chance of this, stated with the estimate: 20%; middle value at least 2.0-fold (0.30 log units) away from the limit.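

Compound 4 sits at a limit of the assay and not at a number, and it shares that limit with one other compound: the limit of > 40000 nM in this assay, at which 2 of the 4 values shown sit. In this assay, on these data alone, bromo in place of cyclopropylmethoxy is an at least 1.8-fold higher number from compound 2 to compound 4 (0.25 log units; that floor lies within the scatter), and bromo in place of hydrogen is an at least 1.5-fold higher number from compound 3 to compound 4 (0.18 log units; that floor lies within the scatter), so both steps are floors that do not clear the scatter, and their true size stays unknown. Unlike hydrogen or cyclopropylmethoxy on this aromatic carbon, bromo leaves no readable number, and the step between compound 1 and compound 4 cannot be read, since both ends are limits.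

As far as these compounds go, how far beyond the limit compound 4 lies stays open. So does whether any group on this carbon, such as an amine, a carboxylic acid or a longer ether chain, would lower the number beyond the scatter.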